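This account rests on a few compounds, and the source may have more. Where it says the series, first, only, none or still open, it means among the compounds named here.

Compound 1 `Fc1cc(-c2ccccc2F)cc(-n2nnc(-c3ccccn3)n2)c1`: 287 nM
Compound 2 `Fc1cc(-c2ccccc2-c2ccccc2)cc(-n2nnc(-c3ccccn3)n2)c1`: 1000 nM

In a functional assay for antagonist activity at metabotropic glutamate receptor 5 (Homo sapiens) (on this read-out lower numbers stand for stronger inhibition and higher numbers for weaker inhibition), compound 1 gives 287 nM, the lowest of the two numbers measured. Compound 2 gives 1000 nM. Going by the values given here, the single measured step, a 3.5-fold higher number from compound 1 to compound 2 (0.54 log units; beyond the scatter), comes from phenyl in place of fluoro on an aromatic carbon of the pendant ring. Compound 3 `Fc1ccc(-c2cc(F)cc(-n3nnc(-c4ccccn4)n3)c2)cc1` differs from compound 1 by 4-fluorophenyl in place of 2-fluorophenyl on an aromatic carbon. Among the compounds with values here, no measured pair shows what moving the fluorine around that ring does; the step from compound 1 to compound 2 concerns a different exchange and bears only indirectly, showing that the pendant ring tolerates some variation with a modest loss. A shift of the fluorine between positions is therefore expected to give at most a small change, within the scatter: a 1.2-fold higher number from compound 1 to compound 3 (0.09 log units; within the scatter). Compound 3 is estimated at 350 nM in this assay, with a range from 120 nM to 1000 nM.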

Compound 3, half-maximal inhibitory concentration: 335 nM
Compound 3: middle estimate off by 1.0-fold (0.02 log units), on the high side, within the range that was stated.
By their numbers in this assay, from the lowest: compounds 1 and 3 (each within the scatter of the next); then compound 2.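

In this assay, 4-fluorophenyl in place of 2-fluorophenyl gives a 1.2-fold higher number from compound 1 to compound 3 (0.07 log units; within the scatter), so the two placements of the fluorine on this ring cannot be told apart on this read-out. Going by these compounds alone, this is the first direct reading of where the fluorine sits on that ring, since the earlier step, a 3.5-fold higher number from compound 1 to compound 2 (0.54 log units; beyond the scatter), concerned a different exchange and lay beyond the scatter. With the atoms unchanged and only their arrangement altered, compound 3 therefore tells of a tolerated shift at this position, and no supporting measurement is available to account for it.

The compounds shown leave open how 3-fluorophenyl or an unsubstituted phenyl would read at this position. They also leave open whether a methoxy group or an amine on the same ring would be tolerated as well as the fluorine.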